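Swapping the quinoline for a dimethoxyphenyl on the enaminone

The source may report more compounds than this note shows. Statements on the series, on what has been measured and on what is new or still open speak of the compounds shown alone.

Compound 1, `O=C(/C=C\Nc1cnc2ccccc2c1)c1nc(-c2ccc(C(F)(F)F)cc2)n2ccccc12`, is tested in a functional assay on A549 cells (Homo sapiens) for cytotoxicity, read by MTT assay, with a stated time of 48 h; a lower number here means a stronger inhibitor, a higher number a weaker inhibitor. There compound 1 shows only a limit, > 30000 nM, and no number is known for it. Its measured neighbour compound 2, `O=C(/C=C\Nc1cnc2ccccc2c1)c1nc(-c2ccccc2)n2ccccc12`, carries hydrogen in place of trifluoromethyl on an aromatic carbon. In this assay compound 2 also returns a limit, > 30000 nM. Among the measured compounds shown here, the step from compound 1 to compound 2 is therefore a step that the two limits leave unreadable from compound 1 to compound 2, and the only evidence available is the limit of > 30000 nM in this assay, at which 2 of the 2 values shown sit, which bears on the trifluoromethyl position and not on the amine side of the molecule.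

The unmeasured compound 3, `COc1ccc(N/C=C\C(=O)c2nc(-c3ccc(C(F)(F)F)cc3)n3ccccc23)cc1OC`, differs from compound 1 on the other side: 3,4-dimethoxyphenyl in place of quinolin-3-yl on an amine nitrogen. For the measured compounds named here, no measured step touches this position, so the data give no direction for the change. With both measured compounds sitting at the limit, the expected step is a number no higher from compound 1 to compound 3 (the limit leaves the size open), meaning compound 3 is most likely to return a limit as well. Compound 3 is therefore estimated at 30000 nM in this assay, with a range from 8000 nM to 100000 nM.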

Compound 3, half-maximal inhibitory concentration: > 30000 nM
Compound 3: a limit, no number; the forecaster's own chance of this, stated with the estimate: 75%; the middle value sits exactly at the limit.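

Compound 1 and compound 3 both stand at a limit in this assay, so no step can be read for 3,4-dimethoxyphenyl in place of quinolin-3-yl on the amine nitrogen. The compounds shown leave open whether any change at either position gives a measurable number in this assay, as all of them rest at one limit: the limit of > 30000 nM in this assay, at which 3 of the 3 values shown sit.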